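Two fluorines on the phenoxy of a compound at the limit

A few compounds are considered here, and "the series" means these few. Any claim that something is new, unique, unknown or untested is made for them only; others in the source may bear on it.

Compound 1 `CCCCCCNS(=O)(=O)NC(=O)Oc1c(C(C)C)cccc1C(C)C`: 21000 nM
Compound 2 `CCCCN(CCCC)S(=O)(=O)NC(=O)Oc1c(C(C)C)cccc1C(C)C`: 1900 nM; 1900 nM (2 entries)
Compound 3 `CC(C)c1cccc(C(C)C)c1OC(=O)NS(=O)(=O)Oc1ccccc1`: > 50000 nM

In an assay on liver for inhibition of sterol O-acyltransferase 1 (Rattus norvegicus), using microsomes (on this read-out higher numbers stand for weaker inhibition and lower numbers for stronger inhibition), compound 1 gives 21000 nM and compound 2 gives 1900 nM; 1900 nM (2 entries). Compound 3 reaches only a limit of this assay, > 50000 nM, and so stands at the limit of > 50000 nM in this assay, at which 1 of the 3 values shown sits, rather than at a number. Among the compounds with values here, the single measured step, an at least 2.3-fold higher number from compound 1 to compound 3 (0.37 log units; beyond the scatter), changes the group on the sulfonyl sulfur and leaves the aromatic ring untouched, so it gives no guide to a ring substitution. Compound 4 `CC(C)c1cccc(C(C)C)c1OC(=O)NS(=O)(=O)Oc1c(F)cccc1F` differs from compound 3 by 2,6-difluorophenyl in place of phenyl on an oxygen. Within the data shown here, with no measured step bearing on this change, no shift beyond the scatter is expected. Compound 4 is estimated at 50000 nM, with a range from 20000 nM to 120000 nM. The expected step, a number no higher from compound 3 to compound 4 (the limit leaves the size open), is thus within the scatter.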

Compound 4, half-maximal inhibitory concentration: 38000 nM
Beside the measured number, compound 4's estimate is 1.3-fold (0.12 log units) above it; measured number inside the range.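

Compound 4 gives a number in this assay, whereas compound 3, with plain phenoxy, reaches only a limit, which leaves the size of the change open: the limit of > 50000 nM in this assay, at which 1 of the 4 values shown sits. All that can be read is a floor, an at least 1.3-fold lower number from compound 3 to compound 4 (0.11 log units; that floor lies within the scatter), so the two fluorines cannot be said to have changed the result. Set against hexylamino on the sulfonyl sulfur, 2,6-difluorophenoxy gives a 1.8-fold higher number from compound 1 to compound 4 (0.26 log units; within the scatter), so these two groups cannot be told apart here.

Going by these compounds, whether a single fluorine, a chlorine or a methoxy on this ring would move the number beyond the scatter stays open. So does whether a dibutylamino group, or another amine, would do better than these ring-bearing groups when compared in a single step.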